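Oral exposure in a thiazolidinone acid series

This account rests on a few compounds, and the source may have more. Where it says the series, first, only, none or still open, it means among the compounds named here.

Measured so far:
compound 1, `O=C(O)CCCSCCN1C(=O)OC[C@@H]1/C=C/[C@@H](O)Cc1cccc(C(F)(F)F)c1`: 6.7%
compound 2, `CCCc1cccc(C[C@H](O)/C=C/[C@H]2CSC(=O)N2CCSCCCC(=O)O)c1`: 6.3%

Both compounds have been run in an in vivo ADME assay on the whole organism for pharmacokinetics, with Rattus norvegicus as the target, at a dose of 1 mg/kg by the oral route; a higher number here means that a larger share of the oral dose reaches the circulation, a lower number that a smaller share of the oral dose reaches the circulation. In this assay compound 1 gives 6.7%, and compound 2 gives 6.3%. The two numbers lie within the scatter of each other, so no order between compound 1 and compound 2 can be read from them; both sit at a low level of oral exposure.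

The next compound is compound 3, `O=C(O)CCCSCCN1C(=O)SC[C@@H]1/C=C/[C@@H](O)Cc1cccc(C(F)(F)F)c1`. It is derived from compound 2 by a single change: trifluoromethyl in place of propyl on an aromatic carbon. The remaining framework of compound 2 is kept.

Going by the values given here, no measured pair in the set isolates this change on its own. Compound 1 already carries the trifluoromethyl on the aromatic ring and gives 6.7%, a number that sits next to the value of compound 2. On that basis the step from compound 2 to compound 3 is expected to be small, a number 0.7 percentage points higher from compound 2 to compound 3 (within the scatter), and not beyond the scatter in either direction. Compound 3 is therefore estimated at 7% in this assay, with a range from 2% to 15%.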

Compound 3, oral bioavailability: 5.5%
Beside the measured number, compound 3's estimate is 1.5 percentage points above it; the range from low to high includes it.
By their numbers in this assay, from the lowest: compounds 3, 2 and 1 (each within the scatter of the next).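

Measured on the shared core, on an aromatic carbon of the six-membered aromatic ring, trifluoromethyl in place of propyl gives a number 0.8 percentage points lower from compound 2 to compound 3 (within the scatter) in this assay and now stands as a directly read step for this change. At this position, the read-out does not separate the two groups, although the exchange removes three carbon atoms and brings in one carbon and three fluorine atoms. Compound 2 and compound 3 both remain at a low level of oral exposure, so this single exchange does not lift the compound out of that level. No measurement at hand bears on the reason for this result.

Still open, going by these compounds, is whether an amine, a nitrile or a longer chain such as pentyl on the same aromatic carbon would give a step beyond the scatter. Also open, on these data alone, is whether an ester in place of the carboxylic acid, with 3-(trifluoromethyl)phenyl kept, would shift oral exposure on this core.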